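From 4-fluorophenyl to 4-methylphenyl: notes on the series

The source may report more compounds than this note shows. Statements on the series, on what has been measured and on what is new or still open speak of the compounds shown alone.

In a functional assay on HCT-116 cells (Homo sapiens) for antiproliferative activity, read by CellTiter-Glo, with a stated time of 72 h (on this read-out lower numbers stand for stronger inhibition and higher numbers for weaker inhibition), compound 1 `O=C(NO)c1ccc(/C=C/c2ccnc(-c3cccc(O)c3)c2)cc1` gives 1610 nM and compound 2 `O=C(NO)c1ccc(/C=C/c2ccnc(-c3cccc(CO)c3)c2)cc1` gives 1700 nM, with a 1.1-fold higher number from compound 1 to compound 2 (0.02 log units; within the scatter). Compound 3 `O=C(NO)c1ccc(/C=C/c2ccnc(-c3ccc(F)cc3)c2)cc1` reads > 10000 nM, which is a limit of the assay and not a number. Compound 4 `Cc1ccc(-c2cc(/C=C/c3ccc(C(=O)NO)cc3)ccn2)cc1` differs from compound 3 by methyl in place of fluoro on an aromatic carbon. Going by the values given here, no measured step makes this exact exchange. The nearest are an at least 6.2-fold higher number from compound 1 to compound 3 (0.79 log units; beyond the scatter) and an at least 5.8-fold higher number from compound 2 to compound 3 (0.76 log units; beyond the scatter). Compound 4 carries neither the hydroxy nor the hydroxymethyl group lost in those steps, so no step beyond the scatter is expected in this assay, and no direction can be favoured. The expected step is a number no higher from compound 3 to compound 4 (the limit leaves the size open). For compound 4 the estimate is 10000 nM, with an expected range from 3500 nM to 30000 nM.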

Compound 4, half-maximal inhibitory concentration: 2390 nM
Estimate against measurement, compound 4: 4.2-fold (0.62 log units) above; the measured number lies below the stated range.
By their numbers in this assay, from the lowest: compounds 1, 2 and 4 (each within the scatter of the next). At a limit, above all of these: compound 3.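

At this position, para to a large group, methyl in place of fluoro makes a difference in this assay (an at least 4.1-fold lower number from compound 3 to compound 4 (0.62 log units; beyond the scatter)). A 4-methylphenyl without hydroxy or hydroxymethyl still reads with the 3-substituted compounds (a 1.4-fold higher number from compound 2 to compound 4 (0.15 log units; within the scatter); a 1.5-fold higher number from compound 1 to compound 4 (0.17 log units; within the scatter)), so the loss of those groups alone does not account for the reading of compound 3. On these data alone, compound 3 stands at a limit and not a number, so the size of its step stays open: the limit of > 10000 nM in this assay, at which 1 of the 4 values shown sits.

As far as these compounds go, whether an amine, a carboxylic acid or a longer chain such as propyl at this position would read like methyl or like fluoro remains open.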